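Notes on the amide substituent in the series

This account rests on a few compounds, and the source may have more. Where it says the series, first, only, none or still open, it means among the compounds named here.

Measured so far, in an assay on CHO cells for agonist activity at G protein-coupled receptor GPR35 (Rattus norvegicus), read by a beta-galactosidase reporter and beta-arrestin recruitment, with a stated time of 90 min; a higher number here means that more compound is needed for the effect, a lower number that less compound is needed:
compound 1, `COc1ccc(C(=O)Nc2cc(Br)cc3c(=O)cc(C(=O)O)oc23)c(Cl)c1`, gives 4170 nM.
compound 2, `O=C(O)c1cc(=O)c2cccc(NC(=O)C3CCCCC3)c2o1`, gives 1200 nM.

Compound 1 stands at the higher of these two numbers. Compound 2 gives the lower number, and the gap between the two values is beyond the usual scatter. For the measured compounds named here, the two compounds differ in more than one place, so no single step joins them and nothing further can be read from the pair.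

Compound 3, `CCOc1ccc(C(=O)Nc2cc(Br)cc3c(=O)cc(C(=O)O)oc23)cc1`, is not yet measured. It differs from compound 1 by 4-ethoxyphenyl in place of 2-chloro-4-methoxyphenyl on a carbonyl carbon. Going by the values given here, no measured pair isolates this change, so there is no step to lean on. The expectation is that the step from compound 1 to compound 3 in this assay is a 1.4-fold lower number from compound 1 to compound 3 (0.14 log units; within the scatter), that is, a change within or only slightly beyond the scatter, with direction uncertain. Compound 3 is therefore estimated at 3000 nM, with a range from 900 nM to 10000 nM.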

Compound 3, half-maximal effective concentration: 1360 nM
Compound 3: the middle estimate sits 2.2-fold (0.34 log units) above what was measured; the measured number falls inside the stated range.
By their numbers in this assay, from the lowest: compounds 2 and 3 (each within the scatter of the next); then compound 1.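

For the compounds shown here, the first single-place step falls on the group on the carbonyl carbon: in this assay, 4-ethoxyphenyl in place of 2-chloro-4-methoxyphenyl gives a 3.1-fold lower number from compound 1 to compound 3 (0.49 log units; beyond the scatter). With the core held fixed, this shows that the number responds to the group at this position, which the earlier pair, differing in more than one place, could not show. No measurement on hand offers an explanation for the step.

The change removes the chlorine and lengthens the alkoxy chain in one move, so the step cannot be assigned to either alteration alone; 4-methoxyphenyl or 2-chloro-4-ethoxyphenyl at this position would separate the two. As far as these compounds go, whether the step carries over to a core without the bromine also remains open.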